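The source may report more compounds than this note shows. Statements on the series, on what has been measured and on what is new or still open speak of the compounds shown alone.

Of the compounds shown here, two have been measured so far in a functional assay on A549 cells (Homo sapiens) for cytotoxicity, read by MTT assay, with a stated time of 72 h; on this read-out higher numbers stand for weaker inhibition and lower numbers for stronger inhibition. Compound 1, `COc1cc2cc(Cc3ccc(O)cc3)c(=O)oc2cc1O`, gives 88100 nM in this assay. Compound 2, `COc1ccc(CCC(=O)c2ccc(O)cc2)c(OC)c1`, gives 89500 nM in this assay. Within the data shown here, compound 2 holds one of only two numbers measured; compound 1, the only other, gives a value that lies within the usual scatter of it, so the two stand together at the weak end of what this read-out can resolve and cannot be told apart.

The account now turns to compound 3, `COc1ccc(CCC(=O)c2ccc(O)cc2)c(O)c1`, which has not yet been measured. It differs from compound 2 in a single place: hydrogen in place of methyl on an oxygen on an aromatic ring. Among the measured compounds shown here, no step between measured compounds of this kind is available, so the size of the change in this assay must be expected rather than read off.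

Given that compound 2 gives 89500 nM and that compound 1, a compound of a different core, gives 88100 nM, the expected step of a 1.1-fold lower number from compound 2 to compound 3 (0.02 log units; within the scatter) is none beyond the scatter. Compound 3 is therefore estimated at 85000 nM, with a range from 40000 nM to 180000 nM.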

Compound 3, half-maximal inhibitory concentration: 12000 nM
Estimate against measurement, compound 3: 7.1-fold (0.85 log units) above, and the stated range ends above it.
By their numbers in this assay, from the lowest: compound 3; then compounds 1 and 2 (each within the scatter of the next).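

Hydrogen in place of methyl on an oxygen on an aromatic ring brings a 7.5-fold lower number from compound 2 to compound 3 (0.87 log units; beyond the scatter) in this assay, the only step so far and one that lies beyond the scatter. Among these compounds, the earlier values, those of compound 1 and compound 2, stood within the scatter of each other and included no pair differing in one place, so they could not show that this position responds at all; the loss of a single methyl, one heavy atom, now shows that it does. Nothing measured here accounts for why methoxy to hydroxy at this position has an effect of this size.

On these data alone, it remains open whether another group on this oxygen, such as an ethyl or a longer chain, would read closer to compound 2 or to compound 3, and how an amine in place of the hydroxy would read. As far as these compounds go, whether methoxy to hydroxy on the core of compound 1 would bring a step of similar size is also open, so this result stands for this one pair only.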